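This account rests on a few compounds, and the source may have more. Where it says the series, first, only, none or still open, it means among the compounds named here.

Measured so far:
- compound 1, `COc1cc(C(c2cc(OC)c(OC)c(OC)c2)[C@@H]2COC(=O)[C@H]2C)cc(OC)c1O` — 29000 nM in a functional assay on A549 cells (Homo sapiens) for inhibition, with stated times of 1 h and 6 h; on this read-out lower numbers stand for stronger inhibition and higher numbers for weaker inhibition
- compound 2, `COc1cc(C(c2cc(OC)c(OC)c(OC)c2)[C@@H]2COC(=O)[C@H]2C)cc(O)c1OC` — 59900 nM in this assay

On this assay compound 2 gives the highest of the two numbers; the nearest value, that of compound 1, is lower, and the gap between the two lies beyond the scatter. Among the measured compounds shown here, no step between measured compounds that differ in a single place is available, so the move to compound 3, `COc1cc(C(c2cc(OC)c(OC)c(OC)c2)[C@@H]2COC(=O)[C@H]2C)cc(OC)c1OC`, has no measured precedent. The change is methyl in place of hydrogen on an oxygen on an aromatic ring; cut one bond further out it reads hydroxy to methoxy. Compound 2 carries the weaker number of the pair, so a small move toward the number of compound 1 is expected, or none beyond the scatter, and for compound 3 the step of a 1.7-fold lower number from compound 2 to compound 3 (0.23 log units; within the scatter) is the estimate. Compound 3 is expected to give 35000 nM, within 12000 nM to 100000 nM.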

Compound 3, half-maximal inhibitory concentration: 125000 nM
Compound 3: middle estimate off by 3.6-fold (0.55 log units), on the low side; measured number above the stated range.
By their numbers in this assay, from the lowest: compound 1; then compound 2; then compound 3.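

In this assay the change from hydroxy to methoxy gives a 2.1-fold higher number from compound 2 to compound 3 (0.32 log units; beyond the scatter) and also a 4.3-fold higher number from compound 1 to compound 3 (0.63 log units; beyond the scatter) and so moves the number the same way in both available cases. Among the compounds shown here, both steps lie beyond the scatter, which makes compound 3, the one compound of the three without a hydroxy, the weakest, and the larger step starts from compound 1. No measurement at hand accounts for this result or for the difference in size between the two steps.

Open, going by these compounds, is whether the hydrogen on the oxygen is what matters, or whether an amine or a fluorine in place of the hydroxy would keep the lower number. Also open, on these data alone, is how an ethoxy or a longer chain on the same oxygen would compare with methoxy.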